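Swapping the amide aryl group: an estimate for compound 4

A few compounds are considered here, and "the series" means these few. Any claim that something is new, unique, unknown or untested is made for them only; others in the source may bear on it.

Compound 1 `O=C(Nc1cccc(-c2oc3cc(-c4ccc(F)cc4)ccc3c(=O)c2O)c1)c1ccc(F)cc1F` gives 26400 nM in a functional assay on HepG2 cells (Homo sapiens) for antiproliferative activity, read by CCK-8 assay, with a stated time of 72 h; a higher number here means a weaker inhibitor, a lower number a stronger inhibitor. Compound 2 `Cc1ccccc1C(=O)Nc1cccc(-c2oc3cc(-c4ccc(F)cc4)ccc3c(=O)c2O)c1` gives 19400 nM in this assay. Compound 3 `O=C(Nc1cccc(-c2oc3cc(-c4ccc(F)cc4)ccc3c(=O)c2O)c1)c1ccc(Br)cc1F` gives > 100000 nM in this assay, and this is a limit of the assay, not a number. Compound 3 is reported only as the limit of > 100000 nM in this assay, at which 1 of the 3 values shown sits, so for compound 3 a limit, not a number, is known.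

Compound 4 `O=C(Nc1cccc(-c2oc3cc(-c4ccc(F)cc4)ccc3c(=O)c2O)c1)c1ccc([N+](=O)[O-])cc1` differs from compound 3 by 4-nitrophenyl in place of 4-bromo-2-fluorophenyl on a carbonyl carbon. Among the compounds with values here, two measured steps bear on this change: an at least 3.7-fold higher number from compound 1 to compound 3 (0.57 log units; beyond the scatter) and an at least 5.1-fold higher number from compound 2 to compound 3 (0.71 log units; beyond the scatter), both showing that the 4-bromo-2-fluorophenyl group went with a weaker result than the other aryl groups tried. Returning to a different aryl group is therefore expected to move the number back toward those of compound 1 and compound 2, though by how much is uncertain. Compound 4 is estimated at 50000 nM in this assay, within 15000 nM to 150000 nM, which means an expected step of an at least 2.0-fold lower number from compound 3 to compound 4 (0.30 log units; that floor lies within the scatter).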

Compound 4, half-maximal inhibitory concentration: 1860 nM
The estimate for compound 4 lay 27-fold (1.43 log units) above the measured number; the measured number lies below the stated range.
By their numbers in this assay, from the lowest: compound 4; then compounds 2 and 1 (each within the scatter of the next). At a limit, above all of these: compound 3.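

The aryl group on this carbonyl carbon can shift the number by far more than the scatter, as the 4-nitrophenyl group stands clearly apart from the 2-methylphenyl group (a 10-fold lower number from compound 2 to compound 4 (1.02 log units; beyond the scatter)) and the 2,4-difluorophenyl group (a 14-fold lower number from compound 1 to compound 4 (1.15 log units; beyond the scatter)) in this assay. The change from the 4-bromo-2-fluorophenyl group is also large (an at least 53-fold lower number from compound 3 to compound 4 (1.73 log units; beyond the scatter)). Compound 3 sits at a limit of the assay, not at a number, so that step is only a floor: (the limit of > 100000 nM in this assay, at which 1 of the 4 values shown sits).

The compounds shown leave open whether the gain follows the nitro group itself or the absence of any group other than hydrogen on the remaining ring carbons. An amine or a carboxylic acid in place of the nitro group would begin to test this.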